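The compounds below may be only part of what the source reports. "The series", "measured", "known", "first", "only" and "open" are said of these compounds alone.

Values in a functional assay on HeLa cells (Homo sapiens) for inhibition, read by CCK-8 assay, with a stated time of 48 h (a higher number here means a weaker inhibitor, a lower number a stronger inhibitor), stand as follows
Compound 1 `O=S(=O)(NCCNC(=S)Nc1cccc(Cl)c1)c1ccc(-c2ccccc2OCc2ccccc2)s1` gives 8400 nM
Compound 2 `O=C(NCCNS(=O)(=O)c1ccc(-c2ccccc2Oc2ccc([N+](=O)[O-])c([N+](=O)[O-])c2)s1)Nc1cc(Cl)cc(Cl)c1` gives a limit, > 20000 nM
Compound 3 `O=C(NCCNS(=O)(=O)c1ccc(-c2ccccc2OCc2ccccc2)s1)Nc1cccc([N+](=O)[O-])c1` gives a limit, > 20000 nM

Compound 3 yields no number and sits at a limit (the limit of > 20000 nM in this assay, at which 2 of the 3 values shown sit). Compound 4 `O=C(NCCNS(=O)(=O)c1ccc(-c2ccccc2OCc2ccccc2)s1)Nc1cc(Cl)cc(Cl)c1` carries 3,5-dichlorophenyl in place of 3-nitrophenyl on an amide-type nitrogen. For the measured compounds named here, one measured step bears on this change (an at least 2.3-fold higher number from compound 1 to compound 3 (0.37 log units; beyond the scatter)), though it is not the same swap. Compound 2 also carries 3,5-dichlorophenyl on an amide-type nitrogen, differs elsewhere, and is held at a limit (> 20000 nM). Only compound 1 gives a number (8400 nM). A modest fall in the number is expected, and the result may well stay at the limit. The expected change is small (an at least 1.6-fold lower number from compound 3 to compound 4 (0.22 log units; that floor lies within the scatter)). Compound 4 is estimated at 12000 nM (expected range 4000 nM to 30000 nM).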

Compound 4, half-maximal inhibitory concentration: > 20000 nM
Compound 4: only a limit was reported; the forecaster's own chance of this, stated with the estimate: 40%; middle value at least 1.6-fold (0.22 log units) away from the limit.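

For the compounds shown here, compound 4 gives only a limit in this assay, so 3,5-dichlorophenyl on this amide-type nitrogen yields no readable number, just as 3-nitrophenyl did not: the limit of > 20000 nM in this assay, at which 3 of the 4 values shown sit. Against the only compound with a number, the step reads an at least 2.3-fold higher number from compound 1 to compound 4 (0.37 log units; beyond the scatter). The steps to compound 4 from compound 2 and compound 3 cannot be read, as both ends are limits.

The compounds shown leave open whether the sulfur or the single chlorine of compound 1 accounts for that step. Going by these compounds, whether an amine or a carboxylic acid on this phenyl ring would give a number also remains open.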